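The source may report more compounds than this note shows. Statements on the series, on what has been measured and on what is new or still open speak of the compounds shown alone.

In an ADME assay on HepG2 2.2.15 cells (Homo sapiens) for cytotoxicity (a lower number here means that less compound is tolerated, a higher number that more compound is tolerated), compound 1 (`CC(C)C(=O)OCCc1c(-c2ccccc2Cl)c2cc(Cl)ccc2[nH]c1=O`) gives 62000 nM and compound 2 (`O=C(OCCc1c(-c2ccccc2Cl)c2cc(Cl)ccc2[nH]c1=O)C1CCCCC1`) gives 38000 nM while compound 3 (`COc1ccccc1/C=C/C(=O)OCCc1c(-c2ccccc2Cl)c2cc(Cl)ccc2[nH]c1=O`) gives 770000 nM as the highest number of the three. Compound 4 (`O=C(/C=C/c1cccc(C(F)(F)F)c1)OCCc1c(-c2ccccc2Cl)c2cc(Cl)ccc2[nH]c1=O`) carries 3-(trifluoromethyl)phenyl in place of 2-methoxyphenyl on a double-bonded chain carbon bound to a double-bonded chain carbon. Within the data shown here, no measured step alters this group alone. The nearest evidence replaces the whole 2-(2-methoxyphenyl)ethenyl group, with a 12-fold higher number from compound 1 to compound 3 (1.09 log units; beyond the scatter) and a 20-fold higher number from compound 2 to compound 3 (1.31 log units; beyond the scatter) as large steps, while a 1.6-fold lower number from compound 1 to compound 2 (0.21 log units; within the scatter) stays within the scatter. Among the measured compounds shown here, compound 3 is the only measured ethenyl compound, so its high number has no second example behind it. A moderate fall is expected, with a 2.6-fold lower number from compound 3 to compound 4 (0.41 log units; beyond the scatter) as the estimated step in this assay. Compound 4 is estimated at 300000 nM with an expected range from 60000 nM to 1000000 nM in this measurement.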

Compound 4, half-maximal cytotoxic concentration: > 1400000 nM
Compound 4 gave a limit, no number (the forecaster's own chance of this, stated with the estimate: 15%); at least 4.6-fold (0.66 log units) between middle value and limit.
By their numbers in this assay, from the lowest: compounds 2 and 1 (each within the scatter of the next); then compound 3. At a limit, above all of these: compound 4.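

Compound 4 gives no number in this assay, only a limit: the limit of > 1400000 nM in this assay, at which 1 of the 4 values shown sits. With 3-(trifluoromethyl)phenyl in place of 2-methoxyphenyl on a double-bonded chain carbon bound to a double-bonded chain carbon, the result is an at least 1.8-fold higher number from compound 3 to compound 4 (0.25 log units; that floor lies within the scatter), so the size of this change stays unresolved. Compound 3 is no longer the lone ethenyl example, as an at least 36-fold higher number from compound 2 to compound 4 (1.56 log units; beyond the scatter) and an at least 22-fold higher number from compound 1 to compound 4 (1.35 log units; beyond the scatter) are also large steps.

From the compounds shown here alone, how far compound 4 lies past its limit stays open. So does whether an ethenyl chain carrying a pyridine ring or an aminophenyl group would hold the number this high.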